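The source may hold more compounds than are shown below. What is called first, only, known or untested is meant among the compounds shown, and "the series" means these compounds.

Measured compounds:
Compound 1, `C=C(Br)C(=O)Nc1cccc(-c2cn3c(-c4ccc(OC)cc4)csc3n2)c1`, gives 200 nM.
Compound 2, `C=C(Br)C(=O)Nc1cccc(-c2cn3nc(Cc4cccc(OC)c4)sc3n2)c1`, gives 2000 nM.
Compound 3, `COc1cccc(Cc2nn3cc(-c4cccc(N)c4)nc3s2)c1`, gives 21000 nM.

These three were tested in a functional assay on L1210 cells (Mus musculus) for inhibition, read by cell counting, with a stated time of 2 days; on this read-out lower numbers stand for stronger inhibition and higher numbers for weaker inhibition. Compound 2 stands second highest of the three numbers; compound 1 gives a lower number and compound 3 a higher one.

Compound 4, `C=C(Br)C(=O)Nc1cccc(-c2cn3nc(-c4cccc(OC)c4)sc3n2)c1`, has not yet been measured. It differs from compound 2 in one place: 3-methoxyphenyl in place of 3-methoxybenzyl on an aromatic carbon.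

Going by the values given here, only one measured step is available, an 11-fold higher number from compound 2 to compound 3 (1.02 log units; beyond the scatter), and it concerns a different change, the loss of the (1-bromoethenyl)carbonyl group from the ring nitrogen, so it does not bear directly on the present step. Compound 1 and compound 2 differ in more than one place, so their values can only be read side by side: compound 1 gives the lower number. There is therefore no direct guide to the size or direction of the present change, and only a modest step is expected, within the scatter or slightly beyond it. For compound 4 the expected step is a 2.0-fold lower number from compound 2 to compound 4 (0.30 log units; within the scatter). The estimate for compound 4 is 1000 nM, with a range from 200 nM to 5000 nM.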

Compound 4, half-maximal inhibitory concentration: 580 nM
Compound 4: the middle estimate sits 1.7-fold (0.24 log units) above what was measured; low and high end bracket the measured number.
By their numbers in this assay, from the lowest: compound 1; then compound 4; then compound 2; then compound 3.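

In this assay, replacing 3-methoxybenzyl, with 9 heavy atoms, by 3-methoxyphenyl, with 8, gives a 3.4-fold lower number from compound 2 to compound 4 (0.54 log units; beyond the scatter). Going by these compounds alone, this is the first measured change on this aromatic carbon of the five-membered ring with 2 nitrogen and 1 sulfur, as the earlier step concerned the group on the nitrogen of the other aromatic ring, and it shows that the number responds to what is attached here, with the shorter attachment on the side of stronger inhibition. The two groups have the same counts of hydrogen-bond donors and acceptors and the same lack of net charge, and no measurement available here explains the shift.

On these data alone, with only these two groups at this position, a single step cannot show a trend, so it remains open whether a longer chain, such as 2-(3-methoxyphenyl)ethyl, would raise the number further, or how an amine or a carboxylic acid on the same carbon would behave. As far as these compounds go, it is also open whether the same swap would shift the number similarly in compound 3, which has a free amino group in place of the (1-bromoethenyl)carbonyl amide.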